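A few compounds are considered here, and "the series" means these few. Any claim that something is new, unique, unknown or untested is made for them only; others in the source may bear on it.

Measured compounds:
Compound 1, `COc1ccc(OC)c(-c2cc(-c3ccccc3)nn2-c2ccc(S(=O)(=O)NC(C)=O)cc2)c1`, gives 7400 nM.
Compound 2, `COc1ccc(OC)c(-c2cc(-c3ccc(Cl)cc3)nn2-c2ccc(S(=O)(=O)NC(C)=O)cc2)c1`, gives 7450 nM.
Compound 3, `NS(=O)(=O)c1ccc(-n2nc(-c3ccccc3)cc2-c2cc(O)ccc2O)cc1`, gives 49600 nM.

All three were tested in a functional assay on cells (Leukemia cell, Homo sapiens) for cytotoxicity, read by sulforhodamine B assay, with a stated time of 48 h; a higher number here means a weaker inhibitor of growth, a lower number a stronger inhibitor of growth. Compound 1 and compound 2 share one core and differ only by chloro in place of hydrogen on an aromatic carbon; that change gave a 1.0-fold higher number from compound 1 to compound 2 (0.00 log units; within the scatter), so the two values cannot be ordered. Compound 3 carries a different core; the difference between the two cores is not broken down here. Its value sits well apart from those of compound 1 and compound 2, and that separation is beyond the scatter.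

Compound 4, `NS(=O)(=O)c1ccc(-n2nc(-c3ccc(Cl)cc3)cc2-c2cc(O)ccc2O)cc1`, has not been measured. It differs from compound 3 by chloro in place of hydrogen on an aromatic carbon, the same kind of change that separates compound 1 from compound 2; the place lines of the two changes read the same, para to a large group on a six-membered aromatic ring of carbon only. Because a 1.0-fold higher number from compound 1 to compound 2 (0.00 log units; within the scatter) left the value unchanged on the first core, compound 4 is expected to stay close to compound 3, with an expected step of a 1.0-fold higher number from compound 3 to compound 4 (0.00 log units; within the scatter). The estimate for compound 4 is therefore 50000 nM, in a range from 20000 nM to 120000 nM.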

Compound 4, concentration for 50% growth inhibition: 5030 nM
The estimate for compound 4 lay 9.9-fold (1.00 log units) above the measured number, and the stated range ends above it.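

In this assay, chloro in place of hydrogen on an aromatic carbon, which turns phenyl into 4-chlorophenyl, did not behave alike on the two cores: the same change on two cores in this assay, a 1.0-fold higher number (0.00 log units; within the scatter) from compound 1 to compound 2 and a 9.9-fold lower number (0.99 log units; beyond the scatter) from compound 3 to compound 4, 9.9-fold (1.00 log units) apart, beyond the scatter of two such steps. On the core of compound 3 the change gave a 9.9-fold lower number from compound 3 to compound 4 (0.99 log units; beyond the scatter), whereas on the core of compound 1 it gave a 1.0-fold higher number from compound 1 to compound 2 (0.00 log units; within the scatter), so the result on one core was no guide to the result on the other in this series. Within the data shown here, this shows that the size of the step depends on the core in these two pairs, but with only one pair per core it does not show which part of the cores is responsible, nor how the change would behave on any third core.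

The compounds shown leave open whether another group in place of the chloro, such as bromo, an amine or a carboxylic acid, would also separate the two cores. They also leave open whether the gap between the two steps would appear in cells other than leukemia cells.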